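Swapping the Chloro Aryl Amide for a Methoxy Analogue

The source may hold more compounds than are shown below. What is called first, only, known or untested is meant among the compounds shown, and "the series" means these compounds.

Compound 1 `CN(C(=O)c1ccccc1)c1ccc2[nH]c(-c3n[nH]c4ccccc34)cc2n1`: 12500 nM
Compound 2 `CN(C(=O)c1ccc(F)cc1)c1ccc2[nH]c(-c3n[nH]c4ccccc34)cc2n1`: 9150 nM
Compound 3 `CN(C(=O)c1ccc(Cl)cc1)c1ccc2[nH]c(-c3n[nH]c4ccccc34)cc2n1`: 2420 nM

In a functional assay on SMMC-7721 cells (Homo sapiens) for antiproliferative activity, read by MTT assay, with a stated time of 72 h (a lower number here means a stronger inhibitor, a higher number a weaker inhibitor), compound 3 gives the lowest number of the three. The steps leading to it read a 5.2-fold lower number from compound 1 to compound 3 (0.71 log units; beyond the scatter) and a 3.8-fold lower number from compound 2 to compound 3 (0.58 log units; beyond the scatter), whereas a 1.4-fold lower number from compound 1 to compound 2 (0.14 log units; within the scatter). Compound 4 `COc1cccc(C(=O)N(C)c2ccc3[nH]c(-c4n[nH]c5ccccc45)cc3n2)c1` carries 3-methoxyphenyl in place of 4-chlorophenyl on a carbonyl carbon. For the measured compounds named here, no measured step involves a methoxy group, so the only guide is that all three measured compounds differ solely on this ring and that the chlorine-bearing compound 3 stands apart. Because the standing of compound 3 rests on a 5.2-fold lower number from compound 1 to compound 3 (0.71 log units; beyond the scatter), taking the chlorine away is expected to give back part of that gain, a step of a 2.5-fold higher number from compound 3 to compound 4 (0.39 log units; beyond the scatter). Compound 4 is therefore estimated at 6000 nM, with a range from 2000 nM to 18000 nM.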

Compound 4, half-maximal inhibitory concentration: 22000 nM
The estimate for compound 4 lay 3.7-fold (0.56 log units) below the measured number, and the stated range ends below it.
By their numbers in this assay, from the lowest: compound 3; then compounds 2, 1 and 4 (each within the scatter of the next, the first and the last beyond it).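

In this assay the 3-methoxyphenyl group does not keep the gain seen with 4-chlorophenyl (a 9.1-fold higher number from compound 3 to compound 4 (0.96 log units; beyond the scatter)) or match 4-fluorophenyl (a 2.4-fold higher number from compound 2 to compound 4 (0.38 log units; beyond the scatter)). Methoxy in place of hydrogen leaves compound 4 within the scatter of the unsubstituted ring (a 1.8-fold higher number from compound 1 to compound 4 (0.25 log units; within the scatter)), so among these compounds, putting a group on this ring does not by itself lower the number. Nothing measured here accounts for these differences.

On these data alone, compound 4 changes both the group and where it sits, so which of the two matters stays open. How an amine or a carboxylic acid on this ring would fare is also unknown.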